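This account rests on a few compounds, and the source may have more. Where it says the series, first, only, none or still open, it means among the compounds named here.

Compound 3, `CNC(=O)c1cccc(S(=O)(=O)Oc2ccc(-c3cncn3C3CCN(C(=O)c4ccc([N+](=O)[O-])cc4)CC3)cc2)c1`: 62 nM
Compound 1, `CNC(=O)c1cccc(S(=O)(=O)Oc2ccc(-c3cncn3C3CCN(C(=O)c4ccc(Cl)c(C(F)(F)F)c4)CC3)cc2)c1`: 112 nM
Compound 2, `COc1ccc(C(=O)N2CCC(n3cncc3-c3ccc(OS(=O)(=O)c4cccc(C#N)c4)cc3)CC2)cc1`: 312 nM

In an assay on HEK293 cells for antagonist activity at P2X purinoceptor 7 (Homo sapiens), read by fluorescence, with a stated time of 2 h (a lower number here means a stronger inhibitor, a higher number a weaker inhibitor), compound 3 has the lowest number shown, with compound 1 within the scatter of it and compound 2 beyond it. Among the measured compounds shown here, the only measured step is a 1.8-fold lower number from compound 1 to compound 3 (0.26 log units; within the scatter), a small one. Compound 4, `CNC(=O)c1cccc(S(=O)(=O)Oc2ccc(-c3cncn3C3CCN(C(=O)c4ccc(OC)cc4)CC3)cc2)c1`, differs from compound 3 by methoxy in place of nitro on an aromatic carbon. For the measured compounds named here, compound 2 also carries a methoxy on that ring but differs from compound 4 elsewhere as well, so compound 2 shows only that such a compound can sit at 312 nM. Going by the values given here, no measured step covers the present change directly, and the one available step was within the scatter. Compound 4 is therefore expected to give 150 nM in this assay, within 50 nM to 450 nM. The expected step is a 2.4-fold higher number from compound 3 to compound 4 (0.38 log units; beyond the scatter), modest and toward a higher number.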

Compound 4, half-maximal inhibitory concentration: 159 nM
Compound 4: the middle estimate sits 1.1-fold (0.03 log units) below what was measured; low and high end bracket the measured number.
By their numbers in this assay, from the lowest: compounds 3, 1, 4 and 2 (each within the scatter of the next, the first and the last beyond it).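

In this assay, methoxy in place of nitro on this ring gives a step beyond the scatter (a 2.6-fold higher number from compound 3 to compound 4 (0.41 log units; beyond the scatter)), while exchanging the whole 4-chloro-3-(trifluoromethyl)phenyl for 4-methoxyphenyl stays within it (a 1.4-fold higher number from compound 1 to compound 4 (0.15 log units; within the scatter)). With the 4-methoxyphenyl held fixed, methylcarbamoyl and cyano are not separated (a 2.0-fold lower number from compound 2 to compound 4 (0.29 log units; within the scatter)). Nothing available explains these differences. Still open, going by these compounds, is where an amine, a carboxylic acid or a plain hydrogen at this position would fall relative to compound 3 and compound 4.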